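The source may report more compounds than this note shows. Statements on the series, on what has been measured and on what is new or still open speak of the compounds shown alone.

Measured so far:
- compound 1, `COc1ccc(Nc2nnc(-c3ccccc3Cl)s2)cc1`, in an assay on isolated protein for inhibition of beta-glucuronidase (Bos taurus), read by spectrophotometry, with a stated time of 30 min (a higher number here means a weaker inhibitor, a lower number a stronger inhibitor), gives 22600 nM
- compound 2, `COc1ccccc1-c1nnc(Nc2ccc(Cl)c(Cl)c2)s1`, in this assay gives 22600 nM

These two compounds share a core but carry their substituents in different arrangements, and on the numbers shown compound 2 stands level with compound 1: the two values agree at the digits printed, so there is no change between them beyond the scatter. Both are weak inhibitors on this scale.

The unmeasured compound, compound 3, `Clc1ccc(Nc2nnc(-c3ccccc3Cl)s2)cc1Cl`, is reached from compound 2 by a single change, (chloro in place of methoxy on an aromatic carbon).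

Going by the values given here, no step between measured compounds is available to guide this change, and the only comparison at hand, compound 1 against compound 2, shows no movement at all despite a larger rearrangement of groups. With that as the sole anchor, the step from compound 2 to compound 3 is expected to stay within the scatter, in no particular direction, as a 1.0-fold lower number from compound 2 to compound 3 (0.01 log units; within the scatter). Compound 3 is therefore estimated at 22000 nM, with a range from 7000 nM to 70000 nM.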

Compound 3, half-maximal inhibitory concentration: 2160 nM
Beside the measured number, compound 3's estimate is 10-fold (1.01 log units) above it; measured number outside the range, below it.
By their numbers in this assay, from the lowest: compound 3; then compounds 1 and 2 (each within the scatter of the next).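

In this assay, replacing methoxy with chloro on an aromatic carbon of a six-membered aromatic ring of carbon only, ortho to a large group, gives a 10-fold lower number from compound 2 to compound 3 (1.02 log units; beyond the scatter) and so marks a stronger inhibitor. Compound 1 and compound 2 differ in more than one place, so their level values could not show what any single group contributes, whereas this single change shows that the group at this position has a large bearing on the reading. No accompanying measurement explains the shift, so the step records what happens and not why it happens.

The compounds shown leave open whether chloro itself matters here or whether removing methoxy is enough, a question that a plain hydrogen, a methyl group or an amine at the same carbon could help to settle. From the compounds shown here alone, it also remains open whether the same swap would have an effect of similar size at another position or on a different set of substituents, since this is a single step in a single pair of compounds.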